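Swapping the aryl group on a nitrile-bearing core

This account rests on a few compounds, and the source may have more. Where it says the series, first, only, none or still open, it means among the compounds named here.

Measured so far:
compound 1, `CCOC(=O)c1cnn(-c2nc(-c3cccc(OC)c3OC)c(C#N)c(=O)n2C)c1N`: 67 ug/mL
compound 2, `CSc1nc(-c2ccc(N(C)C)cc2)c(C#N)c(=O)n1C`: 84 ug/mL

Of the compounds shown here, two have been measured in a functional assay, with a stated time of 10 min; a higher number here means a weaker inhibitor, a lower number a stronger inhibitor. Compound 1 gives 67 ug/mL, the lower of the two numbers. Compound 2 gives 84 ug/mL in this assay, and the gap between the two lies within the scatter, so neither can be called the stronger inhibitor.

The step under consideration leads from compound 1 to compound 3, `CCOC(=O)c1cnn(-c2nc(-c3ccc(Cl)cc3)c(C#N)c(=O)n2C)c1N`, which has not yet been measured. The change is 4-chlorophenyl in place of 2,3-dimethoxyphenyl on an aromatic carbon. For the measured compounds named here, no comparable step between measured compounds is available, so nothing in the data fixes its size or direction. With only that to go on, the author expects a step of a 1.0-fold lower number from compound 1 to compound 3 (0.01 log units; within the scatter) in this assay, that is, none beyond the scatter. Compound 3 is therefore estimated at 65 ug/mL in this assay, within a range from 28 ug/mL to 150 ug/mL.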

Compound 3, half-maximal inhibitory concentration: 94 ug/mL
The estimate for compound 3 lay 1.4-fold (0.16 log units) below the measured number, and the stated range covers the measured number.
By their numbers in this assay, from the lowest: compounds 1, 2 and 3 (each within the scatter of the next).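

In this assay, the first step read at this position, a 1.4-fold higher number from compound 1 to compound 3 (0.15 log units; within the scatter), comes with 4-chlorophenyl in place of 2,3-dimethoxyphenyl on the aromatic carbon. The exchange removes the 2 hydrogen-bond acceptors of the leaving group and brings in a chlorine, yet the two aryl groups cannot be told apart in this read-out, so a considerable change in this substituent does not move the number beyond the scatter. No measured property is at hand to explain this result.

A single step cannot show whether any group at this position would move the number beyond the scatter. From the compounds shown here alone, it remains open how a phenyl group carrying a carboxylic acid or a primary amine would behave here, or a longer alkyl chain in place of the aryl group.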